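Hexyl to 1-phenylethyl on the amide nitrogen

The source may report more compounds than this note shows. Statements on the series, on what has been measured and on what is new or still open speak of the compounds shown alone.

The series shares one core and varies the group on an amide-type nitrogen. In a functional assay on HL-60 cells (Homo sapiens), with a stated time of 4 days (a lower number here means a stronger inhibitor, a higher number a weaker inhibitor), compound 1 `CCCCCCNC(=O)c1[nH]cnc1C(=O)Nc1ccc(Cl)c(Cl)c1` gives 7800 nM. Compound 2 `Cc1ccc(CNC(=O)c2[nH]cnc2C(=O)Nc2ccc(Cl)c(Cl)c2)cc1` gives 15200 nM, and compound 3 `O=C(NCc1ccc(-c2ccccc2)cc1)c1nc[nH]c1C(=O)Nc1ccc(Cl)c(Cl)c1` gives 2900 nM. Compound 1 stands within the scatter of compound 2, while compound 3 lies lower than compound 1 by more than the scatter.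

Compound 4 `C[C@H](NC(=O)c1[nH]cnc1C(=O)Nc1ccc(Cl)c(Cl)c1)c1ccccc1` is still unmeasured. It carries 1-phenylethyl in place of hexyl on an amide-type nitrogen.

Among the measured compounds shown here, the one measured step that bears on this is a 1.9-fold higher number from compound 1 to compound 2 (0.29 log units; within the scatter). There, 4-methylphenyl takes the place of pentyl on a saturated chain carbon bound to an amide-type nitrogen, so a chain also gives way to an aromatic ring. For the measured compounds named here, no measured compound tests a defined stereocentre, and the lower value of compound 3 at 2900 nM keeps the range wide on the low side.

In this assay the expected change is a small rise that stays within the scatter, and the estimated step is a 1.3-fold higher number from compound 1 to compound 4 (0.11 log units; within the scatter). The estimated value for compound 4 is 10000 nM, with an expected range of 4000 nM to 25000 nM.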

Compound 4, half-maximal inhibitory concentration: 5900 nM
Compound 4: middle estimate off by 1.7-fold (0.23 log units), on the high side, and the stated range covers the measured number.
By their numbers in this assay, from the lowest: compound 3; then compounds 4, 1 and 2 (each within the scatter of the next, the first and the last beyond it).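

In this assay the step is a 1.3-fold lower number from compound 1 to compound 4 (0.12 log units; within the scatter) and so 1-phenylethyl and hexyl cannot be told apart on this amide-type nitrogen, which means that an open chain can give way to a six-membered aromatic ring with a defined stereocentre without a change beyond the scatter. Against 4-methylbenzyl the picture differs, with a 2.6-fold lower number from compound 2 to compound 4 (0.41 log units; beyond the scatter) as a modest step beyond the scatter, so two groups that both carry an aromatic ring of carbon only can still be separated at this position. No measurement on hand accounts for that separation.

The compounds shown leave open whether the defined stereocentre of compound 4 contributes at all, a question that the opposite stereoisomer and an unbranched benzyl group would settle. Also open, from the compounds shown here alone, is how this nitrogen responds to a substituent that contains more than carbon, such as a hexyl chain carrying a carboxylic acid or an amine.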